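Three Sulfonyl Aryl Groups and a Fourth Still Unmeasured

The source may hold more compounds than are shown below. What is called first, only, known or untested is meant among the compounds shown, and "the series" means these compounds.

In an assay on isolated protein for displacement of a labelled ligand from metabotropic glutamate receptor 5 (Homo sapiens), with a stated time of 60 min, tested at 1 uM (a lower number here means less inhibition, a higher number more inhibition at the concentration tested (going by the name of the read-out)), compound 1 `CC1CCN(c2c(S(=O)(=O)c3cc(Cl)cc(Cl)c3)cnc3cc(F)ccc23)CC1` gives 87%, compound 2 `CC1CCN(c2c(S(=O)(=O)c3ccc(F)cc3)cnc3cc(F)ccc23)CC1` gives 74.5% and compound 3 `COc1cccc(S(=O)(=O)c2cnc3cc(F)ccc3c2N2CCC(C)CC2)c1` gives 90%. Compound 3 stands highest of the three; the step of a number 3 percentage points higher from compound 1 to compound 3 (within the scatter) lies within the scatter, while a number 15.5 percentage points higher from compound 2 to compound 3 (beyond the scatter) lies beyond the scatter, as does a number 12.5 percentage points lower from compound 1 to compound 2 (beyond the scatter). Compound 4 `Cc1ccc(S(=O)(=O)c2cnc3cc(F)ccc3c2N2CCC(C)CC2)cc1F` differs from compound 3 by 3-fluoro-4-methylphenyl in place of 3-methoxyphenyl on a sulfonyl sulfur. All three measured steps concern the aryl group on the sulfonyl sulfur: two aryl groups gave numbers within the scatter of each other, one gave a modestly lower number. Compound 4 is therefore expected to give about 82%, between 65% and 93%. The expected step is a number 8 percentage points lower from compound 3 to compound 4 (within the scatter), most likely within the scatter or a modest drop.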

Compound 4, a percentage reported as inhibition, at one concentration (the size of the read-out at that concentration, not a potency): 89%
Compound 4: the middle estimate sits 7 percentage points below what was measured, within the range that was stated.
By their numbers in this assay, from the lowest: compound 2; then compounds 1, 4 and 3 (each within the scatter of the next).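

In this assay, the exchange of 3-methoxyphenyl for 3-fluoro-4-methylphenyl on the sulfonyl sulfur gives a number 1 percentage points lower from compound 3 to compound 4 (within the scatter) and the exchange from 3,5-dichlorophenyl gives a number 2 percentage points higher from compound 1 to compound 4 (within the scatter), whereas the exchange from 4-fluorophenyl gives a number 14.5 percentage points higher from compound 2 to compound 4 (beyond the scatter) and leaves compound 2 apart from the other three. The entering group counts no hydrogen-bond acceptor where 3-methoxyphenyl counts one, yet the step stays within the scatter. Nothing available explains why compound 2 stands apart. Open, going by these compounds, is how an amine, a carboxylic acid or a cyclohexyl group would read at this position.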